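Ester to Amide in a Rat Cell Cytotoxicity Series

This account rests on a few compounds, and the source may have more. Where it says the series, first, only, none or still open, it means among the compounds named here.

Of the compounds shown here, two have been tested in an ADME assay on L6 cells (Rattus norvegicus) for cytotoxicity, read by resazurin assay, with a stated time of 72 h; on this read-out higher numbers stand for an effect only at larger amounts of compound and lower numbers for an effect already at smaller amounts. Compound 1, `CCOC(=O)C1=C(C)N/C(=C/c2ccn(-c3ccc(C(F)(F)F)cc3)c2)C1=O`, gives 18000 nM in this assay. Compound 2, `CC1=C(C(=O)OC(C)(C)C)C(=O)/C(=C\c2cc(C)n(-c3ccccc3C(F)(F)F)c2C)N1`, gives 110000 nM in this assay, the higher of the two numbers, with compound 1 standing a good way below it, beyond the usual scatter. Among the compounds with values here, no direct step between the two measured compounds can be drawn, since they differ in several places at once.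

Compound 3, `CC1=C(C(=O)N2CCCCC2)C(=O)/C(=C\c2cc(C)n(-c3ccccc3C(F)(F)F)c2C)N1`, has not yet been measured in this assay. It differs from compound 2 in one place: piperidin-1-yl in place of tert-butoxy on a carbonyl carbon. Within the data shown here, nothing among the measured compounds shows what this particular change does in this assay, so no direction can be drawn from the data. The expectation for the step from compound 2 to compound 3 is therefore a small one, a 1.4-fold lower number from compound 2 to compound 3 (0.14 log units; within the scatter), within the usual scatter. On that basis compound 3 is estimated at 80000 nM in this assay, with a range from 25000 nM to 250000 nM.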

Compound 3, half-maximal effective concentration: 26000 nM
For compound 3 the middle estimate is 3.1-fold (0.49 log units) above the measured one, and the stated range covers the measured number.
By their numbers in this assay, from the lowest: compounds 1 and 3 (each within the scatter of the next); then compound 2.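

Within the data shown here, replacing tert-butoxy with piperidin-1-yl on this carbonyl carbon is the first change that can be read on its own, and in this assay it gives a 4.2-fold lower number from compound 2 to compound 3 (0.63 log units; beyond the scatter) as a modest step beyond the scatter. The group at this place therefore matters on this read-out: with the rest of the molecule unchanged, the compound carrying (piperidin-1-yl)carbonyl shows its effect at smaller amounts than the one carrying tert-butoxycarbonyl. No measurement shown here explains the shift, and this one step cannot separate the departure of tert-butoxy from the arrival of the six-membered ring.

Going by these compounds, what remains open is which part of the new group goes with the step: a dimethylamino group or a morpholin-4-yl group on the same carbonyl carbon would show whether the ring matters, and a free carboxylic acid there would extend the comparison beyond esters and amides. On these data alone, it is also open whether piperidin-1-yl would produce a similar step on the core of compound 1, in place of its ethoxy group.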